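Swapping a Ring Nitrogen in a Phosphate Dithiocarbamate Series

The source may hold more compounds than are shown below. What is called first, only, known or untested is meant among the compounds shown, and "the series" means these compounds.

Of the compounds shown here, three have been measured in an ADME assay on HEK293 cells (Homo sapiens) for inhibition, read by MTT assay, with stated times of 18 h and 4 h; a higher number here means a weaker inhibitor, a lower number a stronger inhibitor. Compound 2 `CCCCCCCCCCOP(=O)(O)OCCSC(=S)N1CCCCC1` carries a piperidin-1-yl ring on its thiocarbonyl carbon, and in this assay compound 2 gives 70700 nM. Compound 1 `CCCCCCCCCCOP(=O)(O)OCCSC(=S)N1CCN(C)CC1` differs from compound 2 only by 4-methylpiperazin-1-yl in place of piperidin-1-yl on a thiocarbonyl carbon. For compound 1 the result in this assay is a limit of the assay, > 100000 nM. The step is an at least 1.4-fold higher number from compound 2 to compound 1 (0.15 log units; that floor lies within the scatter). Compound 3 `CCCCCCOP(=O)(O)OCCSC(=S)N1CCCCC1` keeps the ring of compound 2 but has a shorter chain, a difference of hydrogen in place of butyl on a saturated chain carbon, six bonds along the chain from an oxygen on an unsaturated carbon. For compound 3 the result in this assay is again only a limit, > 100000 nM. That step is an at least 1.4-fold higher number from compound 2 to compound 3 (0.15 log units; that floor lies within the scatter). Two of the three results therefore sit at the same point, (the limit of > 100000 nM in this assay, at which 2 of the 3 values shown sit).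

Compound 4 `CCCCCCOP(=O)(O)OCCSC(=S)N1CCN(C)CC1` has not been measured. Going by the values given here, it differs from compound 3 by 4-methylpiperazin-1-yl in place of piperidin-1-yl on a thiocarbonyl carbon, the same change as the one from compound 2 to compound 1, made on the shorter core of compound 3. Compound 4 is expected to give 150000 nM, with a likely range from 100000 nM to 400000 nM, because compound 3 already gives only the limit > 100000 nM and because the earlier step of an at least 1.4-fold higher number from compound 2 to compound 1 (0.15 log units; that floor lies within the scatter) did not lower the number. The expected step is thus a step that the limit leaves unreadable from compound 3 to compound 4, most probably reported again as a limit rather than a number.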

Compound 4, half-maximal inhibitory concentration: > 100000 nM
Compound 4 ended at the assay's limit (the forecaster's own chance of this, stated with the estimate: 85%); the middle value lies beyond the limit too.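

Neither the step from compound 3 to compound 4 nor the one from compound 1 to compound 4 can be read, as compound 1, compound 3 and compound 4 all end at a limit rather than a number: the limit of > 100000 nM in this assay, at which 3 of the 4 values shown sit.

The compounds shown leave open whether 4-methylpiperazin-1-yl in place of piperidin-1-yl changes the result at all on the core of compound 3, and how compound 1, compound 3 and compound 4 rank against one another.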